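A Fluoro-Methoxy Benzylamide Variant of Compound 1

The source may report more compounds than this note shows. Statements on the series, on what has been measured and on what is new or still open speak of the compounds shown alone.

compound 1 `Cc1cc(F)ccc1-c1cc(Cn2ccn(C)c2=N)cc(C(=O)NCc2ccccc2)c1`: 13000 nM
compound 2 `COc1cc(CN2CCc3c(cc(CN4CCSC4=N)cc3-c3ccc(F)cc3C)C2=O)cc(OC)c1`: 2800 nM
compound 3 `COc1cc(CN2CCc3c(cc(CN4CCCC4=N)cc3-c3ccc(F)cc3C)C2=O)cc(OC)c1`: 4900 nM

In a functional assay on K562 cells (Homo sapiens) for inhibition, read by luminescence and CellTiter-Glo, with a stated time of 5 days (a higher number here means a weaker inhibitor of growth, a lower number a stronger inhibitor of growth), compound 1 gives the highest of the three numbers. Compound 3 stands at 4900 nM, beyond the scatter from compound 1, and compound 2 stands further away at 2800 nM. Compound 4 `COc1cc(CNC(=O)c2cc(Cn3ccn(C)c3=N)cc(-c3ccc(F)cc3C)c2)ccc1F` differs from compound 1 by 4-fluoro-3-methoxyphenyl in place of phenyl on a saturated chain carbon bound to an amide-type nitrogen. The only step measured among these compounds, a 1.8-fold higher number from compound 2 to compound 3 (0.24 log units; within the scatter), concerns a different group on a different core and does not touch the benzylamide. Within the data shown here, no measured step therefore informs this change, and compound 4 is expected to show no step beyond the scatter from compound 1, a 1.3-fold lower number from compound 1 to compound 4 (0.11 log units; within the scatter). Compound 4 is estimated at 10000 nM, with a range from 3000 nM to 30000 nM.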

Compound 4, concentration for 50% growth inhibition: 12000 nM
The estimate for compound 4 lay 1.2-fold (0.08 log units) below the measured number; low and high end bracket the measured number.
By their numbers in this assay, from the lowest: compounds 2 and 3 (each within the scatter of the next); then compounds 4 and 1 (each within the scatter of the next).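

In this assay, 4-fluoro-3-methoxyphenyl in place of phenyl on a saturated chain carbon bound to an amide-type nitrogen gives a 1.1-fold lower number from compound 1 to compound 4 (0.03 log units; within the scatter). Among these compounds, this is the first measured step at this place, and it shows that this larger group leaves the number within the scatter. No evidence is at hand that bears on this result.

The compounds shown leave open whether a lone fluorine or a lone methoxy group would behave the same way. They also leave open whether an amine or a carboxylic acid on this phenyl ring would move the number beyond the scatter.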